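From Cyclopropyloxy to Acetyl on the Shared Core

The source may report more compounds than this note shows. Statements on the series, on what has been measured and on what is new or still open speak of the compounds shown alone.

Measured compounds:
compound 1, `CC(Oc1ccccc1C=O)C1=NCCN1`, gives 0.6
compound 2, `CC(Oc1ccccc1OC1CC1)C1=NCCN1`, gives 0.7

Both compounds were examined in an assay on CHO cells with Alpha-2C adrenergic receptor (Homo sapiens) as the target; on this read-out higher numbers stand for larger maximal responses and lower numbers for smaller maximal responses. Compound 1 and compound 2 share a core and differ only in one group on an aromatic carbon, and the two values sit close together: a number 0.10 higher from compound 1 to compound 2 (within the scatter). Going by the values given here, compound 2 thus stands within the usual scatter of the one other measured compound, so neither can be called the more active.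

The next compound, compound 3, `CC(=O)c1ccccc1OC(C)C1=NCCN1`, is not yet measured. Its change from compound 2 is acetyl in place of cyclopropyloxy on an aromatic carbon. Among the compounds with values here, the only measured step that bears on this position is the one from compound 1 to compound 2, which was within the scatter. Compound 1 carries a formyl group at this place, and acetyl shares a carbonyl with it, so the value for compound 3 is expected to land between the two measured numbers and the step is expected to be small, if anything slightly downward. The step from compound 2 is estimated as a number 0.10 lower from compound 2 to compound 3 (within the scatter). Compound 3 is therefore expected to give about 0.6, with a range from 0.45 to 0.75.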

Compound 3, intrinsic activity: the largest response reached, as a fraction of the reference agonist's: 0.65
Beside the measured number, compound 3's estimate is 0.050 below it, within the range that was stated.
By their numbers in this assay, from the lowest: compounds 1, 3 and 2 (each within the scatter of the next).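

In this assay, acetyl in place of cyclopropyloxy on this aromatic carbon gives a number 0.050 lower from compound 2 to compound 3 (within the scatter), so a group with no ring reads the same as one carrying a three-membered ring, as far as this read-out can tell. Methyl in place of hydrogen on the carbonyl carbon gives a number 0.050 higher from compound 1 to compound 3 (within the scatter), which adds a second small change at this place that does not rise above the scatter, and it is the first view of what happens when the carbonyl group itself is altered rather than replaced. Formyl, acetyl and cyclopropyloxy therefore cannot be told apart here, and no supporting data are available to explain why these groups read alike.

All three groups contain oxygen and are small, so the compounds shown leave open whether an amine, a carboxylic acid, a chlorine atom or a longer chain such as butoxy on this aromatic carbon would shift the maximal response beyond the scatter. They also leave open whether the same tolerance would hold if acetyl were placed on a different carbon of the aromatic ring.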